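Chloro in place of cyano: expectation for compound 4

This account rests on a few compounds, and the source may have more. Where it says the series, first, only, none or still open, it means among the compounds named here.

Within the data shown here, compound 3 `N#Cc1ccc(NC(=O)c2ccc3cccnc3c2O)c(Cl)c1` gives 550 nM in a functional assay on Jurkat cells (Homo sapiens) for cytotoxicity, read by luminescence and CellTiter-Glo, with a stated time of 3 days (on this read-out higher numbers stand for weaker inhibition and lower numbers for stronger inhibition), the highest of the three numbers measured so far. Compound 2 `O=C(Nc1ccc(Cl)cc1)c1ccc2cccnc2c1O` gives 510 nM, which lies within the scatter of compound 3, while compound 1 `N#Cc1cc(Cl)ccc1NC(=O)c1ccc2cccnc2c1O` gives 170 nM, a gap beyond the scatter. Compound 4 `O=C(Nc1ccc(Cl)cc1Cl)c1ccc2cccnc2c1O` has not yet been tested; it differs from compound 3 by chloro in place of cyano on an aromatic carbon. Among the measured compounds shown here, the only measured step, a 3.0-fold higher number from compound 1 to compound 2 (0.48 log units; beyond the scatter), also removed a cyano group, though from compound 1 rather than compound 3, so it bears only loosely here. The near match of 510 nM for compound 2 with 550 nM for compound 3 suggests little movement. Compound 4 is therefore expected to give 500 nM (range 200 nM to 1500 nM), a step of a 1.1-fold lower number from compound 3 to compound 4 (0.04 log units; within the scatter).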

Compound 4, half-maximal inhibitory concentration: 430 nM
Estimate against measurement, compound 4: 1.2-fold (0.07 log units) above, within the range that was stated.
By their numbers in this assay, from the lowest: compound 1; then compounds 4, 2 and 3 (each within the scatter of the next).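

In this assay, at the place para to a large group, chloro and cyano cannot be told apart, with a 1.3-fold lower number from compound 3 to compound 4 (0.11 log units; within the scatter). Chloro in place of hydrogen on compound 2 is equally unresolved, with a 1.2-fold lower number from compound 2 to compound 4 (0.07 log units; within the scatter). Chloro in place of cyano does register starting from compound 1, with a 2.5-fold higher number from compound 1 to compound 4 (0.40 log units; beyond the scatter), so this exchange does not read the same in every compound. No supporting data explain these results. As far as these compounds go, whether an amine or a carboxylic acid at this place would match chloro remains open.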